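Swapping the Chain Terminus on a Shared Core

The source may hold more compounds than are shown below. What is called first, only, known or untested is meant among the compounds shown, and "the series" means these compounds.

Of the compounds shown here, three built on one shared core have been measured in a toxicity assay on HEK-293T cells (Homo sapiens) for cytotoxicity, read by MTT assay, with a stated time of 72 h; on this read-out lower numbers stand for stronger inhibition and higher numbers for weaker inhibition. Compound 1 `O=C1c2c[n+]([O-])c3ccccc3c2C(=O)c2[nH]c3ccccc3c21`, bearing only hydrogen on the aromatic nitrogen, gives 890 nM. Compound 2 `CN1CCN(CCCn2c3c(c4ccccc42)C(=O)c2c[n+]([O-])c4ccccc4c2C3=O)CC1` gives 170 nM, and compound 3 `CN(C)CCCCCn1c2c(c3ccccc31)C(=O)c1c[n+]([O-])c3ccccc3c1C2=O` gives 70 nM, the lowest of the three numbers. Attaching a chain to that nitrogen lowers the number in both cases: a 5.2-fold lower number from compound 1 to compound 2 (0.72 log units; beyond the scatter) and a 13-fold lower number from compound 1 to compound 3 (1.10 log units; beyond the scatter). Changing the end of the chain matters less: a 2.4-fold lower number from compound 2 to compound 3 (0.39 log units; beyond the scatter). Compound 4 `O=C1c2c[n+]([O-])c3ccccc3c2C(=O)c2c1c1ccccc1n2CCCCn1ccnc1` differs from compound 3 in one place: 1H-imidazol-1-yl in place of (dimethylamino)methyl on a saturated chain carbon, four bonds along the chain from an aromatic nitrogen. For the measured compounds named here, the one measured change of a chain end was modest, so a modest shift is expected here, leaning toward a higher number. Compound 4 is therefore estimated in this assay at 150 nM, between 60 nM and 400 nM, which means an expected step of a 2.1-fold higher number from compound 3 to compound 4 (0.33 log units; beyond the scatter).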

Compound 4, half-maximal inhibitory concentration: 280 nM
Beside the measured number, compound 4's estimate is 1.9-fold (0.27 log units) below it; low and high end bracket the measured number.
By their numbers in this assay, from the lowest: compound 3; then compounds 2 and 4 (each within the scatter of the next); then compound 1.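

In this assay, a chain ending in a ring still keeps a clear gain over the bare core (compound 1), with 4-(1H-imidazol-1-yl)butyl on the aromatic nitrogen (a 3.2-fold lower number from compound 1 to compound 4 (0.50 log units; beyond the scatter)). The 1H-imidazol-1-yl end does not match the dimethylamino end, however (a 4.0-fold higher number from compound 3 to compound 4 (0.60 log units; beyond the scatter)). Against the 4-methylpiperazine chain end, the step stays small (a 1.6-fold higher number from compound 2 to compound 4 (0.22 log units; within the scatter)), so those two compounds cannot be told apart. From the compounds shown here alone, whether a morpholine end or a 5-(1H-imidazol-1-yl)pentyl chain would bring the number closer to that of compound 3 remains open. Nothing available here explains these shifts.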